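The source may report more compounds than this note shows. Statements on the series, on what has been measured and on what is new or still open speak of the compounds shown alone.

In a functional assay on HT-29 cells (Homo sapiens) for inhibition, with a stated time of 72 h (a higher number here means a weaker inhibitor, a lower number a stronger inhibitor), three compounds sharing one core have been measured: compound 1 `COc1ccc(S(=O)(=O)N2CCc3cccc(-c4ccco4)c32)cc1` gives 62.5 nM, compound 2 `COc1ccc(S(=O)(=O)N2CCc3cccc(-c4cccnc4)c32)cc1` gives 76.3 nM, and compound 3 `COc1ccc(S(=O)(=O)N2CCc3cccc(-c4ccccc4)c32)cc1` gives 96.5 nM. Compound 3 therefore stands within the scatter of both others. Compound 4 `COc1ccc(S(=O)(=O)N2CCc3cccc(-c4ccc(C#N)cc4)c32)cc1` has cyano in place of hydrogen on an aromatic carbon of the phenyl group of compound 3, para to a large group: cyano in place of hydrogen on an aromatic carbon. The closest evidence comes from exchanges among furan-2-yl, pyridin-3-yl and phenyl: a 1.2-fold higher number from compound 1 to compound 2 (0.09 log units; within the scatter), a 1.5-fold higher number from compound 1 to compound 3 (0.19 log units; within the scatter) and a 1.3-fold higher number from compound 2 to compound 3 (0.10 log units; within the scatter), all within the scatter. None of them adds a cyano group, so they offer only indirect guidance, and no step beyond the scatter is expected. The expected step is a 1.1-fold higher number from compound 3 to compound 4 (0.06 log units; within the scatter). For compound 4 the estimate is 110 nM, with an expected range of 40 nM to 300 nM.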

Compound 4, half-maximal inhibitory concentration: 24.2 nM
Beside the measured number, compound 4's estimate is 4.5-fold (0.66 log units) above it, and the stated range ends above it.
By their numbers in this assay, from the lowest: compound 4; then compounds 1, 2 and 3 (each within the scatter of the next).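

Until now, exchanging the aromatic group at this position on the shared core in this assay had moved the number only within the scatter, but cyano in place of hydrogen, para to a large group, gives (a 4.0-fold lower number from compound 3 to compound 4 (0.60 log units; beyond the scatter)), a step beyond the scatter. The 4-cyanophenyl group also separates from the other two groups, with (a 3.2-fold lower number from compound 2 to compound 4 (0.50 log units; beyond the scatter)) and (a 2.6-fold lower number from compound 1 to compound 4 (0.41 log units; beyond the scatter)), both beyond the scatter. Nothing available here accounts for these steps.

On these data alone, whether an amine, a carboxylic acid or a methoxy group at that place would give a step of similar size remains open. So does the outcome of cyano on the pyridin-3-yl or furan-2-yl group.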